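A few compounds are considered here, and "the series" means these few. Any claim that something is new, unique, unknown or untested is made for them only; others in the source may bear on it.

Measured in a functional assay on MCF7 cells (Homo sapiens) for antiproliferative activity; on this read-out lower numbers stand for stronger inhibition and higher numbers for weaker inhibition:
- Compound 1 `CC(C)=CCc1cc(C(=O)Nc2cc3ccc(OCC4CCN(C)C4)c(C)c3oc2=O)ccc1O`: 1550 nM
- Compound 2 `CC(C)=CCc1cc(C(=O)Nc2cc3ccc(OCCCN4CCCCC4)c(C)c3oc2=O)ccc1O`: > 50000 nM, which is a limit of the assay and not a number
- Compound 3 `CCNCCCOc1ccc2cc(NC(=O)c3ccc(O)c(CC=C(C)C)c3)c(=O)oc2c1C`: 980 nM

The measurements fall into two groups: a 1.6-fold lower number from compound 1 to compound 3 (0.20 log units; within the scatter), whereas an at least 51-fold lower number from compound 2 to compound 3 (1.70 log units; beyond the scatter). Compound 3 therefore shares its range with compound 1 only.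

Compound 4 `CCN(CC)CCCOc1ccc2cc(NC(=O)c3ccc(O)c(CC=C(C)C)c3)c(=O)oc2c1C` differs from compound 3 by ethyl in place of hydrogen on an amine nitrogen, turning ethylamino into diethylamino. The closest guide is compound 2, whose piperidin-1-yl nitrogen also carries no hydrogen, and the large step there reads an at least 51-fold lower number from compound 2 to compound 3 (1.70 log units; beyond the scatter). Compound 1 goes against a simple reading of that step: its ring nitrogen carries no hydrogen either, and yet a 1.6-fold lower number from compound 1 to compound 3 (0.20 log units; within the scatter). These two steps pull in opposite directions, so only a modest move towards a higher number is expected, namely a 2.6-fold higher number from compound 3 to compound 4 (0.41 log units; beyond the scatter) in this assay. For compound 4 the estimated value is 2500 nM, with an expected range from 800 nM to 15000 nM.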

Compound 4, half-maximal inhibitory concentration: 6390 nM
Estimate against measurement, compound 4: 2.6-fold (0.41 log units) below; the range from low to high includes it.
By their numbers in this assay, from the lowest: compounds 3 and 1 (each within the scatter of the next); then compound 4. At a limit, above all of these: compound 2.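

In this assay, putting ethyl in place of the hydrogen on the amine nitrogen of compound 3 moves the number beyond the scatter (a 6.5-fold higher number from compound 3 to compound 4 (0.81 log units; beyond the scatter)), so ethylamino and diethylamino are not interchangeable at this place. Compound 4 also separates from compound 1 (a 4.1-fold higher number from compound 1 to compound 4 (0.62 log units; beyond the scatter)), yet compound 1 has no hydrogen on its nitrogen either and stays within the scatter of compound 3, so that missing hydrogen alone does not set the number. Diethylamino still reads clearly better than piperidin-1-yl (an at least 7.8-fold lower number from compound 2 to compound 4 (0.89 log units; beyond the scatter)), but this step is only a minimum, as compound 2 stands at a limit of the assay and not at a number: the limit of > 50000 nM in this assay, at which 1 of the 4 values shown sits.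

On these data alone, it remains open whether dimethylamino or a morpholine ring on the same chain would fall nearer compound 3 or compound 2. As far as these compounds go, how a longer chain carrying ethylamino would read is also open.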